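The compounds below may be only part of what the source reports. "The series", "measured", "known", "first", "only" and "open" are said of these compounds alone.

Compound 1 `CCOc1cc(=O)n(CCCO)c2c1CC(CC=C(C)C)C(C)(C)C2` is tested in a functional assay on PANC-1 cells (Homo sapiens) for inhibition, read by MTT assay, with a stated time of 24 h, tested at 10 uM (on this read-out lower numbers stand for less inhibition and higher numbers for more inhibition at the one concentration tested (going by the name of the read-out)), where compound 1 gives 16.6%. Compound 2 `CC(C)=CCOc1cc(=O)n(CCCO)c2c1CC(CC=C(C)C)C(C)(C)C2` gives 7.5% in this assay, and compound 3 `CC(C)=CCC1Cc2c(OCCCNS(=O)(=O)c3ccc(Cl)cc3)cc(=O)n(CCCO)c2CC1(C)C` gives 9.8%. Compound 1 thus holds the highest of the three numbers, but both of its steps fall within the scatter: a number 9.1 percentage points lower from compound 1 to compound 2 (within the scatter) and a number 6.8 percentage points lower from compound 1 to compound 3 (within the scatter), so no ordering among the three can be claimed.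

Compound 4 `CC(C)=CCC1Cc2c(OC(=O)Nc3ccccc3F)cc(=O)n(CCCO)c2CC1(C)C` has not yet been measured. Its difference from compound 1 is (2-fluorophenyl)carbamoyl in place of ethyl on an oxygen on an aromatic ring. Both measured steps touch the same oxygen on the aromatic ring of the shared core, the first replacing part of the chain on that oxygen, the second adding a substituent to it, and neither moved this assay beyond the scatter. On that basis compound 4 is expected to stay near compound 1, with an expected step of a number 3.6 percentage points lower from compound 1 to compound 4 (within the scatter). Compound 4 is estimated to give 13% in this assay, with a range from 2% to 32%.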

Compound 4, a percentage reported as inhibition, at one concentration (the size of the read-out at that concentration, not a potency): 0%
Compound 4: the middle estimate sits 13 percentage points above what was measured; the whole stated range lies above it.
By their numbers in this assay, from the lowest: compounds 4, 2, 3 and 1 (each within the scatter of the next, the first and the last beyond it).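

In this assay, among the compounds shown here, the earlier changes at this oxygen on an aromatic ring stayed within the scatter, but (2-fluorophenyl)carbamoyl in place of ethyl gives a number 16.6 percentage points lower from compound 1 to compound 4 (beyond the scatter), the first step that clears it. The position is therefore not indifferent to every change, although the same group in place of 3-methylbut-2-en-1-yl gives only a number 7.5 percentage points lower from compound 2 to compound 4 (within the scatter), so this result separates compound 4 from compound 1 but not from compound 2. Nothing available explains the lower number for compound 4.

As far as these compounds go, it remains open whether the step follows from the carbamoyl link or from the 2-fluorophenyl ring. A plain phenylcarbamoyl or an acetyl group on the same oxygen would help separate the two.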